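A few compounds are considered here, and "the series" means these few. Any claim that something is new, unique, unknown or untested is made for them only; others in the source may bear on it.

Measured numbers in an assay on Sf9 cells for inhibition of protein deacetylase HDAC6 (Homo sapiens), read by fluorescence, with a stated time of 40 min, tested at 100 nM; a lower number here means less inhibition, a higher number more inhibition at the concentration tested (going by the name of the read-out):

Compound 1, `Cc1ccccc1-n1nc(-c2ccccc2)nc1CNc1ccc(C(=O)NO)cc1`, compound 1 gives 57.1%.
Compound 2, `O=C(NO)c1ccc(NCc2nc(-c3ccc(Br)cc3)nn2-c2ccccc2)cc1`, compound 2 gives 54.7%.
Compound 3, `COc1ccc(-n2nc(-c3ccc(O)cc3)nc2CNc2ccc(C(=O)NO)cc2)cc1`, compound 3 gives 70.3%.

On the numbers shown compound 2 stands lowest of the three, but the gap to compound 1 is within the scatter, so compound 1 and compound 2 cannot be told apart here. Compound 3 lies beyond the scatter above compound 2 and is the only one of the three that does.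

Compound 4, `Cc1cccc(-c2nc(CNc3ccc(C(=O)NO)cc3)n(-c3ccccc3)n2)c1`, is not yet measured in this assay. It differs from compound 2 in one place: 3-methylphenyl in place of 4-bromophenyl on an aromatic carbon. The change is the 3-methylphenyl in place of the 4-bromophenyl, on an aromatic carbon of the five-membered aromatic ring with 3 nitrogen, between two ring nitrogen atoms.

Among the measured compounds shown here, no step between measured compounds covers this exchange. Compound 1, which carries a phenyl at that place, and compound 2 sit within the scatter of each other, so a change of the group at this aromatic carbon has so far shown no step beyond the scatter in this assay. For compound 4 the expectation is therefore a step of no more than the scatter, in either direction.

Compound 4 is expected to give about 56%, with a range from 42% to 70%. The step of a number 1.3 percentage points higher from compound 2 to compound 4 (within the scatter) is expected to lie within the scatter.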

Compound 4, a percentage reported as inhibition, at one concentration (the size of the read-out at that concentration, not a potency): 64.1%
The estimate for compound 4 lay 8.1 percentage points below the measured number, and the stated range covers the measured number.
By their numbers in this assay, from the lowest: compounds 2, 1, 4 and 3 (each within the scatter of the next, the first and the last beyond it).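

In this assay, the exchange of 4-bromophenyl for 3-methylphenyl gives the first step read directly at this aromatic carbon of the five-membered ring: a number 9.4 percentage points higher from compound 2 to compound 4 (within the scatter). The two groups have the same count of heavy atoms, one six-membered aromatic ring of carbon only and no hydrogen-bond donors or acceptors, but one carries bromine and the other an all-carbon methyl substituent; compound 2 and compound 4 cannot be told apart in this read-out. No measured property is available that bears on this step.

The exchange alters the substituent and its place on the phenyl ring together, so 4-methylphenyl or 3-bromophenyl would be needed to read those two parts separately. Going by these compounds, both groups are also substituted phenyl rings of carbon apart from the bromine, so the response of this position to an amine, a carboxylic acid or a longer chain remains open.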